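The source may hold more compounds than are shown below. What is called first, only, known or untested is meant among the compounds shown, and "the series" means these compounds.

Compound 1 `Cc1cccc(-n2nncc2CN2C(=O)C3(C(C#N)=C(N)Oc4c3c3nc5ccccc5nc3c3ccccc43)c3ccccc32)c1` gives 39600 nM in a functional assay on A549 cells (Homo sapiens) for antiproliferative activity, read by MTT assay, with a stated time of 48 h; a lower number here means a stronger inhibitor, a higher number a weaker inhibitor. Compound 2 `N#CC1=C(N)Oc2c(c3nc4ccccc4nc3c3ccccc23)C12C(=O)N(Cc1cnnn1-c1ccc(Cl)cc1)c1ccccc12` reaches only the limit of this assay, > 50000 nM. Compound 3 `N#CC1=C(N)Oc2c(N)cc3nc4ccccc4nc3c2C12C(=O)N(Cc1cnnn1-c1ccc([N+](=O)[O-])cc1)c1ccccc12` likewise gives only a limit, > 50000 nM.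

Compound 3 therefore stands at the limit of > 50000 nM in this assay, at which 2 of the 3 values shown sit, so its true number is not known. Compound 4 `N#CC1=C(N)Oc2c(N)cc3nc4ccccc4nc3c2C12C(=O)N(Cc1cnnn1-c1c(Cl)cc(Cl)cc1Cl)c1ccccc12` differs from it in one place: 2,4,6-trichlorophenyl in place of 4-nitrophenyl on an aromatic nitrogen. Among the compounds with values here, the one measured step that also swaps the group on that aromatic nitrogen is an at least 1.2-fold higher number from compound 1 to compound 2 (0.10 log units; that floor lies within the scatter), whose floor cannot be told apart from the scatter. No larger shift is expected for compound 4 from this change alone. For compound 4 the estimated step is a number no higher from compound 3 to compound 4 (the limit leaves the size open). Compound 4 is therefore expected to give about 50000 nM in this assay, with a range from 20000 nM to 120000 nM, and most probably again only a limit.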

Compound 4, half-maximal inhibitory concentration: > 50000 nM
Compound 4: only a limit was reported (the forecaster's own chance of this, stated with the estimate: 75%); the middle value lies on the limit itself.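

Compound 3 and compound 4 each give only a limit, so no step between them can be read: the limit of > 50000 nM in this assay, at which 3 of the 4 values shown sit.

The compounds shown leave open whether 4-nitrophenyl and 2,4,6-trichlorophenyl differ at all in their effect on this number.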